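Swapping a Methoxyphenyl for a Pyridine Ring: Solubility Outlook

The source may report more compounds than this note shows. Statements on the series, on what has been measured and on what is new or still open speak of the compounds shown alone.

compound 1 `CCOC(=O)C1=C(C)N/C(=C/c2cc(C)n(-c3ccc(Cl)cc3)c2C)C1=O`: 1.6 ug/mL
compound 2 `CCOC(=O)C1=C(C)N/C(=C/c2cc(C)n(-c3ccc(OC)cc3)c2C)C1=O`: 3.1 ug/mL
compound 3 `CCOC(=O)C1=C(C)N/C(=C/c2cc(C)n(-c3cccc(OC)c3)c2C)C1=O`: 6.3 ug/mL

In a physicochemical assay for solubility, read by nephelometry, measured as kinetic solubility, at pH 2.0 (a lower number here means a less soluble compound, a higher number a more soluble compound), compound 3 stands highest of the three measured compounds, ahead of compound 2 by a 2.0-fold higher number from compound 2 to compound 3 (0.31 log units; beyond the scatter) and ahead of compound 1 by a 3.9-fold higher number from compound 1 to compound 3 (0.60 log units; beyond the scatter). Compound 4 `CCOC(=O)C1=C(C)N/C(=C/c2cc(C)n(-c3cccnc3)c2C)C1=O` has not yet been measured in this assay. It differs from compound 3 in one place: pyridin-3-yl in place of 3-methoxyphenyl on an aromatic nitrogen.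

The measured steps that bear on this change are the ones that alter the group on the same aromatic nitrogen: a 3.9-fold higher number from compound 1 to compound 3 (0.60 log units; beyond the scatter) and a 2.0-fold higher number from compound 2 to compound 3 (0.31 log units; beyond the scatter), both modest, and a 1.9-fold higher number from compound 1 to compound 2 (0.29 log units; within the scatter), which stays within the scatter. Going by the values given here, none of these steps brings in a ring containing a hetero atom, so the change to compound 4 has no direct precedent among the measured compounds; every change at this position so far has shifted this assay by a modest amount at most.

Compound 4 is therefore expected to give 15 ug/mL in this assay, with a range from 5 ug/mL to 50 ug/mL. The expected step in this assay is a 2.4-fold higher number from compound 3 to compound 4 (0.38 log units; beyond the scatter), a rise beyond the scatter but of uncertain size.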

Compound 4, solubility: > 50 ug/mL
Compound 4: a limit, no number; the forecaster's own chance of this, stated with the estimate: 5%; at least 3.3-fold (0.52 log units) between middle value and limit.
By their numbers in this assay, from the lowest: compounds 1 and 2 (each within the scatter of the next); then compound 3. At a limit, above all of these: compound 4.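

Compound 4 gives a limit rather than a number in this assay: the limit of > 50 ug/mL in this assay, at which 1 of the 4 values shown sits.

Even so, the step to pyridin-3-yl on the aromatic nitrogen can be read as an at least 7.9-fold higher number from compound 3 to compound 4 (0.89 log units; beyond the scatter) and is set beside two wider comparisons, an at least 16-fold higher number from compound 2 to compound 4 (1.20 log units; beyond the scatter) and an at least 31-fold higher number from compound 1 to compound 4 (1.49 log units; beyond the scatter), both large. Among the earlier compounds, swaps between substituted phenyl rings at this position moved the number by a modest amount at most, so this is the first ring with a hetero atom here and the first group to give a large step.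

As far as these compounds go, how far compound 4 lies past its limit stays open. From the compounds shown here alone, the change also removes the methoxy group and puts a nitrogen into the ring in one move, so the contribution of each remains open, as do the unsubstituted phenyl, pyridin-2-yl and pyridin-4-yl groups.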